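The source may hold more compounds than are shown below. What is called first, only, known or untested is meant among the compounds shown, and "the series" means these compounds.

Three compounds share one core, and a fourth is to be tried. Compound 1 `O=C1O[C@@H](CN2CCC(O)CC2)CN1c1ccc(-n2cc(-c3ccccn3)cn2)c(F)c1` carries 4-hydroxypiperidin-1-yl on a saturated chain carbon bound to a saturated ring carbon; in an ADME assay on L02 cells (Homo sapiens) for cytotoxicity, read by MTT assay, with a stated time of 48 h (a lower number here means a stronger inhibitor, a higher number a weaker inhibitor), compound 1 reaches only the limit of > 400 ug/mL. Compound 2 `O=C1O[C@@H](Cn2ccnn2)CN1c1ccc(-n2cc(-c3ccccn3)cn2)c(F)c1` carries 1H-1,2,3-triazol-1-yl at that place, and in this assay compound 2 gives 49 ug/mL. Compound 3 `CCNC(=O)NC[C@H]1CN(c2ccc(-n3cc(-c4ccccn4)cn3)c(F)c2)C(=O)O1` carries (ethylcarbamoyl)amino there. In this assay compound 3 also reaches only the limit of > 400 ug/mL. Thus compound 3 stands with compound 1 at the limit of > 400 ug/mL in this assay, at which 2 of the 3 values shown sit, and the step of an at least 8.1-fold higher number from compound 2 to compound 3 (0.91 log units; beyond the scatter) is the only readable one touching it; the step that the two limits leave unreadable from compound 1 to compound 3 cannot be read.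

Compound 4 `CNC(=O)[C@H]1CN(c2ccc(-n3cc(-c4ccccn4)cn3)c(F)c2)C(=O)O1` changes a different place: methylcarbamoyl in place of ((ethylcarbamoyl)amino)methyl on a saturated ring carbon. Among the compounds with values here, no measured step alters a group on a saturated ring carbon, so the measured steps give only indirect guidance; two of the three compounds sit at the limit, and compound 3 is one of them. Compound 4 is therefore expected to stay weak, with an estimated step of an at least 1.1-fold lower number from compound 3 to compound 4 (0.05 log units; that floor lies within the scatter) and an estimated value of 350 ug/mL in this assay, between 120 ug/mL and 450 ug/mL.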

Compound 4, half-maximal inhibitory concentration: 217 ug/mL
Beside the measured number, compound 4's estimate is 1.6-fold (0.21 log units) above it; measured number inside the range.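

Within the data shown here, this is the first measured change of a whole group on the saturated ring carbon next to the ring oxygen, and in this assay methylcarbamoyl at this place gives a readable number rather than a limit. The comparisons with the two compounds at the limit are an at least 1.8-fold lower number from compound 3 to compound 4 (0.26 log units; that floor lies within the scatter) and an at least 1.8-fold lower number from compound 1 to compound 4 (0.26 log units; that floor lies within the scatter); both are only floors within the scatter, so neither establishes a real change. Among these compounds, the one exact comparison is a 4.4-fold higher number from compound 2 to compound 4 (0.65 log units; beyond the scatter), so (1H-1,2,3-triazol-1-yl)methyl remains the group with the lowest number among the four compounds.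

On these data alone, the true distance of compound 4 from compounds 1 and 3 stays open, as their values are limits and not numbers: the limit of > 400 ug/mL in this assay, at which 2 of the 4 values shown sit. As far as these compounds go, how a carboxylic acid or a longer chain in place of methylcarbamoyl would read at this ring carbon also stays open.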